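A few compounds are considered here, and "the series" means these few. Any claim that something is new, unique, unknown or untested is made for them only; others in the source may bear on it.

Measured so far:
Compound 1 `O=S(=O)(Nc1ccc(-c2nc3ccccc3o2)cc1)c1ccc(Cl)s1`: > 100000 nM
Compound 2 `O=S(=O)(Nc1ccc(-c2nc3ccccc3o2)cc1)c1cccc(O)c1`: > 100000 nM

Both entries come from an ADME assay on HEK293 cells (Homo sapiens) for cytotoxicity, read by resazurin assay, with a stated time of 48 h; on this read-out lower numbers stand for higher toxicity in this test and higher numbers for lower toxicity in this test. Compound 1 gives > 100000 nM, which is a limit of the assay and not a number. On these data alone, compound 2 gives > 100000 nM, again only a limit, so its true position is unknown.

Compound 3 `O=S(=O)(Nc1ccc(-c2nc3ccccc3o2)cc1)c1cccc(Cl)c1` has chloro in place of hydroxy on an aromatic carbon. Within the data shown here, one measured step bears on this change: a step that the two limits leave unreadable from compound 1 to compound 2. It has no readable size, so it offers no size to carry over. What the two compounds share is the limit of > 100000 nM in this assay, at which 2 of the 2 values shown sit. No step beyond the usual scatter is expected, because the limit of > 100000 nM in this assay, at which 2 of the 2 values shown sit, is all that these compounds show, and a further limit is the likeliest result. The estimated step is a number no higher from compound 2 to compound 3 (the limit leaves the size open). For compound 3 the expected value is 100000 nM, with an estimated range from 45000 nM to 200000 nM.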

Compound 3, half-maximal cytotoxic concentration: > 100000 nM
Compound 3: a limit, no number (the forecaster's own chance of this, stated with the estimate: 85%); the middle value lies on the limit itself.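

No step can be read between compound 1, compound 2 and compound 3, since each value is a limit of the assay and not a number: the limit of > 100000 nM in this assay, at which 3 of the 3 values shown sit.

Where their true values lie, and whether the exchanged groups make any difference in this assay, stays open.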